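The source may hold more compounds than are shown below. What is called first, only, known or untested is meant among the compounds shown, and "the series" means these compounds.

Compound 1 `C[C@H](NC(=O)c1nc(Br)c2cccnc2c1N[C@H]1CC[C@H](N)CC1)c1ccc(F)cc1`: > 10000 nM (a limit, not a number)
Compound 2 `N[C@H]1CC[C@H](Nc2c(C(=O)NCc3cccs3)nc(Br)c3cccnc23)CC1`: 4100 nM

Within the data shown here, in a functional assay on MDA-MB-435 cells (Homo sapiens) for cytotoxicity, read by MTT assay, with a stated time of 72 h (a lower number here means a stronger inhibitor, a higher number a weaker inhibitor), compound 2 gives 4100 nM, the only true number so far. Compound 1 reports only a limit, > 10000 nM.

Compound 3 `N[C@H]1CC[C@H](Nc2c(C(=O)NC3CCCCC3)nc(Br)c3cccnc23)CC1` differs from compound 2 by cyclohexyl in place of (thiophen-2-yl)methyl on an amide-type nitrogen. Among the measured compounds shown here, the one measured step at this nitrogen is an at least 2.4-fold lower number from compound 1 to compound 2 (0.38 log units; beyond the scatter), a modest one that favoured (thiophen-2-yl)methyl. Losing that group should therefore cost a little, so a small move toward a higher number is expected: a 1.7-fold higher number from compound 2 to compound 3 (0.23 log units; within the scatter). The estimate for compound 3 is 7000 nM, with an expected range of 2500 nM to 20000 nM.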

Compound 3, half-maximal inhibitory concentration: > 10000 nM
Compound 3: only a limit was reported; the forecaster's own chance of this, stated with the estimate: 35%; at least 1.4-fold (0.15 log units) between middle value and limit.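

Putting cyclohexyl in place of (thiophen-2-yl)methyl on the amide-type nitrogen gives an at least 2.4-fold higher number from compound 2 to compound 3 (0.38 log units; beyond the scatter) in this assay, so a second replacement, this time a non-aromatic ring of carbon only, also falls short of compound 2. Compound 3 reports only a limit, like compound 1, and the step between those two cannot be read. How far either falls short is capped by the assay itself: the limit of > 10000 nM in this assay, at which 2 of the 3 values shown sit.

Which part of (thiophen-2-yl)methyl matters stays open. Benzyl or (furan-2-yl)methyl on this nitrogen would test whether the sulfur is needed, or only an aromatic ring.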